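Pyrimidin-2-yl for 1-hydroxyethyl: an open question on exposure

A few compounds are considered here, and "the series" means these few. Any claim that something is new, unique, unknown or untested is made for them only; others in the source may bear on it.

Three related compounds have been followed in an ADME assay on the whole organism (plasma, strain 129/SvEvBrd x C57BL/6) for pharmacokinetics, with Mus musculus as the target, at a dose of 10 mg/kg by the oral route; a lower number here means less compound in the circulation, a higher number more compound in the circulation at the dose given. Here compound 1 `CC(=O)c1nc([C@@H](O)[C@H](O)[C@H](O)CO)cn1C` gives 10000 ng.h/mL and compound 2 `CC(O)c1nc([C@@H](O)[C@H](O)[C@H](O)CO)c[nH]1` gives 10300 ng.h/mL, two values that lie within the scatter of each other. Compound 3 `CC(=O)N/N=C(\C)c1nc([C@@H](O)[C@H](O)[C@H](O)CO)c[nH]1` gives 1030 ng.h/mL, a clearly smaller number than the other two and beyond the scatter. Compound 2 therefore shares the high end of this small set with compound 1.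

The next structure is compound 4 `OC[C@@H](O)[C@@H](O)[C@H](O)c1c[nH]c(-c2ncccn2)n1`, which has pyrimidin-2-yl in place of 1-hydroxyethyl on an aromatic carbon. Going by the values given here, no measured pair shows what this exact swap does. The nearest guide is a loose one: compared with compound 2, compound 3 carries a larger group and gives 1030 ng.h/mL. A drop in this assay is therefore expected, though a smaller drop than that one. The expected change is a 3.4-fold lower number from compound 2 to compound 4 (0.54 log units; beyond the scatter), an estimate that lies somewhat beyond the scatter. Compound 4 is estimated at 3000 ng.h/mL, with an expected range of 700 ng.h/mL to 12000 ng.h/mL.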

Compound 4, area under the concentration-time curve: 799 ng.h/mL
The estimate for compound 4 lay 3.8-fold (0.57 log units) above the measured number; low and high end bracket the measured number.
By their numbers in this assay, from the lowest: compounds 4 and 3 (each within the scatter of the next); then compounds 1 and 2 (each within the scatter of the next).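

In this assay, the swap of 1-hydroxyethyl for pyrimidin-2-yl gives a 13-fold lower number from compound 2 to compound 4 (1.11 log units; beyond the scatter). Going by these compounds alone, this is the first direct reading of a change on this aromatic carbon, and it shows that the group held here can matter greatly for exposure after an oral dose. Compound 4 now sits with compound 3 at the low end of the set, within the scatter of each other, so two different groups larger than 1-hydroxyethyl both read low here.

Nothing measured here accounts for the drop. Open, as far as these compounds go, is whether the step follows the added size, the aromatic ring, its ring nitrogen atoms or the loss of the hydroxyl group, and how a plain phenyl ring or a small amine in this place would read.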